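One Tail Exchanged on Compound 2

A few compounds are considered here, and "the series" means these few. Any claim that something is new, unique, unknown or untested is made for them only; others in the source may bear on it.

Of the compounds shown here, two have so far been measured in an assay on HEK293 cells for antagonist activity at solute carrier family 2, facilitated glucose transporter member 4 (Homo sapiens), with stated times of 5 min and 6 min; a lower number here means a stronger inhibitor, a higher number a weaker inhibitor. Compound 1, `Oc1cccc(CNCc2ccncc2)c1`, is the smaller of the two, and in this assay compound 1 gives 20000 nM. Compound 2, `COc1ccc(C(=O)N(Cc2ccncc2)Cc2cccc(OCc3cccc(OC)c3)c2)cc1`, shares part of its framework with compound 1 but is built out into a larger amide; in this assay compound 2 gives 11000 nM. Compound 2 has the lower of the two numbers, yet its gap to compound 1 lies within the scatter, so the two cannot be told apart on these data.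

Compound 3, `COc1ccc(C(=O)N(Cc2ccncc2)Cc2cccc(OCCc3ccc(F)cc3)c2)cc1`, has not yet been measured. It differs from compound 2 in one place: 4-fluorobenzyl in place of 3-methoxyphenyl on a saturated chain carbon bound to an oxygen on an aromatic ring. Read one bond further out, a 3-methoxybenzyl group becomes a 2-(4-fluorophenyl)ethyl group. Among the measured compounds shown here, no measured pair shows this kind of exchange, so nothing here tells its size. The expected step is therefore a 1.1-fold lower number from compound 2 to compound 3 (0.04 log units; within the scatter), with no preferred direction and not beyond the scatter. Compound 3 is accordingly estimated at 10000 nM, with a range from 3000 nM to 35000 nM.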

Compound 3, half-maximal inhibitory concentration: 1700 nM
Estimate against measurement, compound 3: 5.9-fold (0.77 log units) above; measured number outside the range, below it.
By their numbers in this assay, from the lowest: compound 3; then compounds 2 and 1 (each within the scatter of the next).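

In this assay, this position on the ether oxygen proves able to move the number: exchanging the 3-methoxybenzyl group for the 2-(4-fluorophenyl)ethyl group gives a 6.5-fold lower number from compound 2 to compound 3 (0.81 log units; beyond the scatter). The leaving and entering parts both hold 8 heavy atoms and one six-membered aromatic ring of carbon only, so the gain comes without any rise in that count. Even so, several things change together, as the methoxy oxygen goes, a fluorine arrives and the benzyl link becomes an ethyl link, and nothing measured here accounts for the step.

Going by these compounds, what stays open is which of those changes carries the step, since this single pair cannot separate them. A plain 2-phenylethyl group would isolate the role of the fluorine, a 4-fluorobenzyl group on the same oxygen would isolate the role of the chain, and a longer chain such as 3-phenylpropyl would show whether the trend in chain length continues or reverses.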